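Aryl Swap on the Ring Nitrogen: Outlook for Compound 3

The source may hold more compounds than are shown below. What is called first, only, known or untested is meant among the compounds shown, and "the series" means these compounds.

Compound 2 `Cc1ccc(-n2nncc2CN2C(=O)C3(C(C#N)=C(N)Oc4c3c3nc5ccccc5nc3c3ccccc43)c3ccccc32)c(C)c1` stands at the limit of the assay in an ADME assay on L02 cells (Homo sapiens) for antiproliferative activity, read by MTT assay, with a stated time of 48 h; a lower number here means a stronger inhibitor, a higher number a weaker inhibitor: in this assay compound 2 gives > 50000 nM, a limit rather than a number. Compound 1 `Cc1cc(C)cc(-n2nncc2CN2C(=O)C3(C(C#N)=C(N)Oc4c3c3nc5ccccc5nc3c3ccccc43)c3ccccc32)c1` in this assay gives > 50000 nM, likewise a limit. The step that the two limits leave unreadable from compound 1 to compound 2 cannot be read, as both values sit at the limit (the limit of > 50000 nM in this assay, at which 2 of the 2 values shown sit). Compound 3 `Cc1ccc(Cl)cc1-n1nncc1CN1C(=O)C2(C(C#N)=C(N)Oc3c2c2nc4ccccc4nc2c2ccccc32)c2ccccc21` carries the change (5-chloro-2-methylphenyl in place of 2,4-dimethylphenyl on an aromatic nitrogen). Within the data shown here, no measured step speaks to this change beyond the two limits, so no shift beyond the scatter is expected, and compound 3 is expected to remain at the limit, estimated at 50000 nM (range 20000 nM to 150000 nM). The implied step is expected to be a number no higher from compound 2 to compound 3 (the limit leaves the size open).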

Compound 3, half-maximal inhibitory concentration: > 50000 nM
Compound 3: no number, only a limit; the forecaster's own chance of this, stated with the estimate: 85%; the middle value sits exactly at the limit.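

Compound 3 gives only a limit, as do compound 1 and compound 2, so the steps that link them cannot be read: the limit of > 50000 nM in this assay, at which 3 of the 3 values shown sit.

The compounds shown leave open whether any aryl swap on the aromatic nitrogen would give a readable number in this assay.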